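Cytotoxicity After Replacing Methoxycarbonyl With Methyl

A few compounds are considered here, and "the series" means these few. Any claim that something is new, unique, unknown or untested is made for them only; others in the source may bear on it.

Of the compounds shown here, two built on one shared core have been tested in an ADME assay on Huh-7 cells (Homo sapiens) for cytotoxicity, read by a luciferase reporter and WST assay, with a stated time of 3 days; on this read-out lower numbers stand for higher toxicity in this test and higher numbers for lower toxicity in this test. Compound 1 `COc1ccc(NC(=O)c2c(NO)cc(-c3ccccc3)oc2=O)cc1` carries a methoxy group on its outer ring. In this assay compound 1 gives > 20000 nM, which is a limit of the test and not a number. Compound 2 `COC(=O)c1ccc(NC(=O)c2c(NO)cc(-c3ccccc3)oc2=O)cc1` carries a methoxycarbonyl group in that place. In this assay compound 2 gives > 20000 nM, again a limit rather than a number. The step that the two limits leave unreadable from compound 1 to compound 2 is therefore unreadable, since both values sit at the limit of > 20000 nM in this assay, at which 2 of the 2 values shown sit. So compound 2 stands at the limit of this assay, with no number above or below it to compare.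

Compound 3 `Cc1ccc(NC(=O)c2c(NO)cc(-c3ccccc3)oc2=O)cc1` differs from compound 2 by methyl in place of methoxycarbonyl on an aromatic carbon. Among the compounds with values here, the only measured step, from compound 1 to compound 2, was unreadable, so it gives no size and no direction for this change. The most reasonable expectation is that compound 3 again shows no toxicity within the range of this assay. Compound 3 is therefore estimated at 30000 nM, in a range from 10000 nM to 100000 nM, which means an expected step that the limit leaves unreadable from compound 2 to compound 3.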

Compound 3, half-maximal cytotoxic concentration: > 20000 nM
Compound 3 gave a limit, no number (the forecaster's own chance of this, stated with the estimate: 80%); the middle value does not contradict the limit.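

Within the data shown here, no step between compound 1, compound 2 and compound 3 can be read, since in this assay all three give a limit and not a number: the limit of > 20000 nM in this assay, at which 3 of the 3 values shown sit.

The compounds shown leave open how far the toxicity of each lies from that limit, and whether the group on the outer ring changes it at all.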